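The compounds below may be only part of what the source reports. "The series", "measured", "known", "first", "only" and "open" are said of these compounds alone.

Among the measured compounds shown here, in a functional assay on MCF7 cells (Homo sapiens) for inhibition, read by MTT assay, with a stated time of 72 h (on this read-out higher numbers stand for weaker inhibition and lower numbers for stronger inhibition), compound 3 `COc1cc2c(Oc3ccc(NC(=O)c4nn(-c5cccc(C(F)(F)F)c5)cc(C)c4=O)cc3)ccnc2cc1OCCCCCCC(=O)NO` gives 750 nM, the lowest of the three numbers so far, while compound 1 `COc1cc2c(Oc3ccc(NC(=O)c4nn(-c5ccc(C)cc5C)cc(C)c4=O)cc3)ccnc2cc1OCCCCCCC(=O)NO` gives 2430 nM and compound 2 `COc1cc2c(Oc3ccc(NC(=O)c4nn(-c5ccccc5C)cc(C)c4=O)cc3)ccnc2cc1OCC(=O)NO` gives 8780 nM. Compound 4 `COc1cc2c(Oc3ccc(NC(=O)c4nn(-c5cccc(C)c5)cc(C)c4=O)cc3)ccnc2cc1OCCCCCCC(=O)NO` changes one group of compound 3: methyl in place of trifluoromethyl on an aromatic carbon. The closest measured guide is a 3.2-fold lower number from compound 1 to compound 3 (0.51 log units; beyond the scatter). Compound 2 differs from compound 3 in more than one place, so it gives no clean comparison. Compound 4 has lost the trifluoromethyl and carries only methyl on that ring, as compound 1 at 2430 nM does, so a modest rise towards that number is expected in this assay. The estimated change is a 2.0-fold higher number from compound 3 to compound 4 (0.30 log units; within the scatter). For compound 4 the estimate is 1500 nM, with an expected range of 700 nM to 3300 nM.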

Compound 4, half-maximal inhibitory concentration: 1680 nM
Compound 4: the middle estimate sits 1.1-fold (0.05 log units) below what was measured; the range from low to high includes it.
By their numbers in this assay, from the lowest: compound 3; then compounds 4 and 1 (each within the scatter of the next); then compound 2.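

In this assay, among the compounds shown here, the step of a 2.2-fold higher number from compound 3 to compound 4 (0.35 log units; beyond the scatter) is the first clean look at this place on the ring: with only trifluoromethyl exchanged for methyl, the number moves beyond the scatter. The step of a 1.4-fold lower number from compound 1 to compound 4 (0.16 log units; within the scatter) lies within the scatter, so 3-methylphenyl and 2,4-dimethylphenyl cannot be told apart in this assay. No measurement at hand explains the difference between trifluoromethyl and methyl. Still open, going by these compounds, is how an amine or a carboxylic acid at this place on the ring would read.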